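The compounds below may be only part of what the source reports. "The series", "measured", "known", "first", "only" and "open" are said of these compounds alone.

Measured so far:
compound 1, `COc1ccc2c(ccn2S(=O)(=O)c2ccccc2)c1`, in this assay 127 nM
compound 2, `CN(C)c1cccc2c1ccn2S(C)(=O)=O`, in this assay 4720 nM

In an assay on isolated protein for displacement of a labelled ligand from 5-hydroxytryptamine receptor 6 (Homo sapiens), read by scintillation counting, with a stated time of 1 h (a lower number here means a stronger inhibitor, a higher number a weaker inhibitor), compound 2 gives 4720 nM, the highest of the two numbers. Its nearest neighbour, compound 1, gives 127 nM, a gap beyond the scatter; the two structures differ in more than one place, so the pair shows only that much. Compound 3 `CN(C)c1cccc2c1ccn2S(=O)(=O)C1CCCCC1` has not yet been measured in this assay. It differs from compound 2 in one place: cyclohexyl in place of methyl on a sulfonyl sulfur. Among the compounds with values here, no step between measured compounds covers this change. A step toward a lower number, beyond the scatter, is expected for compound 3, since compound 1 gives 127 nM with a ring rather than a methyl on the sulfonyl sulfur, though compound 1 also differs elsewhere. Compound 3 is estimated at 800 nM, range 150 nM to 4000 nM, which means an expected step of a 5.9-fold lower number from compound 2 to compound 3 (0.77 log units; beyond the scatter).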

Compound 3, inhibition constant: 4890 nM
The estimate for compound 3 lay 6.1-fold (0.79 log units) below the measured number, outside the stated range (above it).
By their numbers in this assay, from the lowest: compound 1; then compounds 2 and 3 (each within the scatter of the next).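

In this assay, cyclohexyl and methyl on a sulfonyl sulfur whose other neighbour is an aromatic nitrogen cannot be told apart: the result is a 1.0-fold higher number from compound 2 to compound 3 (0.02 log units; within the scatter), so the five additional carbons and the six-membered non-aromatic ring register no separation at this position. The earlier pair could not show this, as compound 1 and compound 2 differ in more than one place, and a ring on the sulfonyl sulfur, when non-aromatic and on the core of compound 2, is now seen not to separate from methyl. No measured evidence is available to explain this result.

It remains open which of the differences between compound 1 and compound 2 accounts for their gap. Also open, as far as these compounds go, is whether a longer chain on the sulfonyl sulfur, or an amine carried on the cyclohexyl ring, would separate from methyl and cyclohexyl.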